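The compounds below may be only part of what the source reports. "The series", "measured", "known", "first", "only" and "open" are said of these compounds alone.

Measured so far: compound 1 `Cc1cc(C)cc(S(=O)(=O)c2c(C(=O)NCC(=O)NCc3ccco3)[nH]c3ccc(Cl)cc23)c1`, > 50000 nM; compound 2 `Cc1cc(C)cc(S(=O)(=O)c2c(C(=O)NC(C)C(=O)NC(C)c3ccccc3)[nH]c3ccc(Cl)cc23)c1`, 21700 nM.

In an ADME assay on MT4 cells (Homo sapiens) for cytotoxicity, read by MTT assay (on this read-out lower numbers stand for higher toxicity in this test and higher numbers for lower toxicity in this test), compound 1 gives only a limit, > 50000 nM, rather than a number, and it sits at the limit of > 50000 nM in this assay, at which 1 of the 2 values shown sits. In this assay compound 2 gives 21700 nM. Compound 3 `Cc1cc(C)cc(S(=O)(=O)c2c(C(=O)NCC(=O)NCc3ccccc3F)[nH]c3ccc(Cl)cc23)c1` differs from compound 1 by 2-fluorophenyl in place of furan-2-yl on a saturated chain carbon bound to an amide-type nitrogen. Among the compounds with values here, no measured step of this kind is at hand, so the change is expected to move the read-out by no more than the usual scatter, and compound 3 is expected to give about 50000 nM, between 20000 nM and 100000 nM, which corresponds to an expected step of a number no higher from compound 1 to compound 3 (the limit leaves the size open).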

Compound 3, half-maximal cytotoxic concentration: > 47300 nM
Compound 3: a limit, no number; the forecaster's own chance of this, stated with the estimate: 60%; the middle value does not contradict the limit.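

Within the data shown here, compound 1 and compound 3 both give only limits in this assay, so no step between them can be read. The compounds shown leave open whether 2-fluorophenyl in place of furan-2-yl changes the read-out at all.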